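Adding a Methyl to the Anilino Ring of Compound 2

The compounds below may be only part of what the source reports. "The series", "measured", "known", "first", "only" and "open" are said of these compounds alone.

Compound 1, `COC(=O)c1c(Nc2ccc(C)cc2)sc(C(=O)c2ccc(OC)cc2)c1C`: "not active" (no number reported) in a functional assay, with a stated time of 150 min, tested at 25 ug/mL; a lower number here means a weaker effect, a higher number a stronger effect of the compound at the concentration tested.
Compound 2, `COC(=O)c1c(Nc2ccccc2)sc(C(=O)c2ccc(C)cc2)c1C`: 8.16% in this assay.

Within the data shown here, compound 2 stands as the only compound with a number in this assay; compound 1 is recorded there without one. Compound 3, `COC(=O)c1c(Nc2ccc(C)cc2)sc(C(=O)c2ccc(C)cc2)c1C`, differs from compound 2 by methyl in place of hydrogen on an aromatic carbon. Among the measured compounds shown here, no step between measured compounds shows what this change does, so its size is open; given the weak read-out of compound 2, a step in either direction beyond the scatter seems unlikely. Compound 3 is expected to give 7%, within 0% to 18%, a step of a number 1.2 percentage points lower from compound 2 to compound 3 (within the scatter) that is expected to lie within the scatter.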

Compound 3, a percentage reported as activity, at one concentration (the size of the read-out at that concentration, not a potency): "not active" (no number reported)
Nothing numeric was reported for compound 3; there is nothing to compare the estimate with.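

Among these compounds, compound 3 carries no number in this assay, and no step from compound 2 to compound 3 can be read. As far as these compounds go, what phenyl to 4-methylphenyl does to this read-out stays open. No other measurement shown offers an explanation.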